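The source may hold more compounds than are shown below. What is called first, only, known or untested is meant among the compounds shown, and "the series" means these compounds.

Two compounds share a common core and differ only in the substitution of one aromatic ring. Compound 1 `COc1ccc(-c2cc(/C=C/C(=O)c3ccc(N)cc3)[nH]n2)cc1` carries a single methoxy group on that ring, while compound 2 `COc1cc(-c2cc(/C=C/C(=O)c3ccc(N)cc3)[nH]n2)cc(OC)c1OC` carries three. In a functional assay on NCI/ADR-RES cells (Homo sapiens) for inhibition, read by sulforhodamine B assay, with a stated time of 48 h (a lower number here means a stronger inhibitor of growth, a higher number a weaker inhibitor of growth), compound 1 gives 2860 nM. In this assay compound 2 gives 3800 nM. These two numbers lie within the usual scatter of each other, so on the numbers available compound 2 is not separated from compound 1 at all. Compound 3 `COc1ccc(-c2cc(/C=C/C(=O)c3ccc(N)cc3)[nH]n2)cc1OC` has not yet been measured. It differs from compound 2 in one place: hydrogen in place of methoxy on an aromatic carbon. For the measured compounds named here, no step between measured compounds corresponds to this particular change; the only comparison available is the pair of compound 1 and compound 2, whose values show no separation beyond the scatter even though their methoxy substitution differs. On that basis the expected step of a 1.2-fold lower number from compound 2 to compound 3 (0.07 log units; within the scatter) is small, within the scatter, and in no particular direction. The estimate for compound 3 in this assay is 3200 nM, with a range from 1300 nM to 8000 nM.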

Compound 3, concentration for 50% growth inhibition: 6210 nM
Estimate against measurement, compound 3: 1.9-fold (0.29 log units) below; the range from low to high includes it.
By their numbers in this assay, from the lowest: compounds 1, 2 and 3 (each within the scatter of the next, the first and the last beyond it).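

Hydrogen in place of methoxy on this aromatic carbon, ortho to a methoxy group and meta to a large group, gives a 1.6-fold higher number from compound 2 to compound 3 (0.21 log units; within the scatter) in this assay and so stays within the scatter; with the other methoxy groups in place, this position does not clearly separate hydrogen from methoxy. Methoxy in place of hydrogen on an aromatic carbon gives a 2.2-fold higher number from compound 1 to compound 3 (0.34 log units; beyond the scatter) and is the first step in this small set to lie beyond the scatter, although it is modest and points toward a weaker inhibitor of growth. The two steps therefore show that the same kind of exchange can be read differently depending on the other substituents on the ring, but no measurement at hand explains this difference.

The compounds shown leave open whether a group other than methoxy at this carbon, such as a hydroxyl group, a fluorine atom or an ethoxy group, would move the number further in either direction. They also leave open how the shared core behaves with no methoxy group on this ring at all, or with an amine in place of the methoxy groups.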